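The source may hold more compounds than are shown below. What is called first, only, known or untested is meant among the compounds shown, and "the series" means these compounds.

Among the measured compounds shown here, compound 1 `Cc1cc(/C=C/C#N)cc(C)c1Oc1cc(Nc2ccc(C#N)cc2)c(N)cc1C(F)(F)F` stands lowest of the three numbers so far in a physicochemical assay for solubility, with a stated time of 4 h, at pH 7.4 (a higher number here means a more soluble compound, a lower number a less soluble compound), at 0.24 ug/mL. Compound 2 `Cc1cc(/C=C/C#N)cc(C)c1Oc1cc(Nc2ccc(C#N)cc2)c(N)cc1CO` gives 3.23 ug/mL, and compound 3 `CNC(=O)c1cc(N)c(Nc2ccc(C#N)cc2)cc1Oc1c(C)cc(CCC#N)cc1C` gives 8.28 ug/mL. Compound 4 `Cc1cc(/C=C/C#N)cc(C)c1Oc1cc(Nc2ccc(C#N)cc2)c(N)cc1C(N)=O` differs from compound 1 by carbamoyl in place of trifluoromethyl on an aromatic carbon. For the measured compounds named here, the one measured step that bears on this change is a 13-fold higher number from compound 1 to compound 2 (1.13 log units; beyond the scatter); compound 3 differs from the others in more than one place, so only its value can be read. On that basis a step upward, beyond the scatter and of roughly that size, is expected in this assay. Compound 4 is estimated at 4 ug/mL, within a range of 1 ug/mL to 14 ug/mL, which is expected to mean a 17-fold higher number from compound 1 to compound 4 (1.22 log units; beyond the scatter).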

Compound 4, solubility: 0.63 ug/mL
Compound 4: the middle estimate sits 6.3-fold (0.80 log units) above what was measured; the measured number lies below the stated range.
By their numbers in this assay, from the lowest: compound 1; then compound 4; then compound 2; then compound 3.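

In this assay, replacing trifluoromethyl at this position does not give one fixed gain: carbamoyl yields a small rise (a 2.6-fold higher number from compound 1 to compound 4 (0.42 log units; beyond the scatter)), whereas hydroxymethyl yields a large one (a 13-fold higher number from compound 1 to compound 2 (1.13 log units; beyond the scatter)). The two entering groups also stand apart from each other (a 5.1-fold lower number from compound 2 to compound 4 (0.71 log units; beyond the scatter)), so the size of the step depends on which group enters, not only on the loss of trifluoromethyl. Nothing available explains this gap.

From the compounds shown here alone, whether an amine or a carboxylic acid at this position would land nearer carbamoyl or hydroxymethyl remains open.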